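A few compounds are considered here, and "the series" means these few. Any claim that something is new, unique, unknown or untested is made for them only; others in the source may bear on it.

In a functional assay on the whole organism (strain Kunming) with Mus musculus as the target, with a stated time of 0.5 h (a lower number here means that less compound is needed, a higher number that more compound is needed for the effect), two related esters have been measured so far. Compound 1 (`COc1cc(OC)c(OC)cc1/C=C/COC(=O)/C=C/c1ccc(Br)cc1`) gives 446 umol/kg, and compound 2 (`COc1cc(OC)c(OC)cc1/C=C/COC(=O)/C=C/c1ccc(F)cc1`) gives 449 umol/kg, so compound 2 stands level with compound 1, within the scatter. Compound 3 (`COc1ccc(/C=C/C(=O)OC/C=C/c2cc(OC)c(OC)cc2OC)cc1`) keeps the core of compound 2 but has methoxy in place of fluoro on an aromatic carbon, para to a large group: methoxy in place of fluoro on an aromatic carbon. For the measured compounds named here, only one measured step bears on this change, fluoro in place of bromo on an aromatic carbon, and it amounts to a 1.0-fold higher number from compound 1 to compound 2 (0.00 log units; within the scatter). Going by the values given here, that step shows no size beyond the scatter, but no measured compound here carries methoxy at this place, so the evidence is thin. No clear shift in either direction is therefore expected, and the estimated change is a 1.0-fold lower number from compound 2 to compound 3 (0.01 log units; within the scatter). For compound 3, the expected value is 440 umol/kg, with an estimated range from 210 umol/kg to 900 umol/kg.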

Compound 3, dose for half-maximal effect: 634 umol/kg
Beside the measured number, compound 3's estimate is 1.4-fold (0.16 log units) below it; the measured number falls inside the stated range.
By their numbers in this assay, from the lowest: compounds 1, 2 and 3 (each within the scatter of the next).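

Methoxy brings to this place what neither halogen did, an oxygen and a hydrogen-bond acceptor, yet in this assay the result is a 1.4-fold higher number from compound 2 to compound 3 (0.15 log units; within the scatter) and a 1.4-fold higher number from compound 1 to compound 3 (0.15 log units; within the scatter). Bromo, fluoro and methoxy therefore cannot be told apart at this position in this assay, so a non-halogen group with two heavy atoms is accommodated here without a step beyond the scatter. Nothing available here accounts for this result.

From the compounds shown here alone, it remains open whether a group of a different kind at this place, such as an amine, a carboxylic acid or a longer alkoxy chain, would give a step beyond the scatter. Also open, going by these compounds, is whether changes elsewhere on the shared core would matter more than those at this position.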